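The source may hold more compounds than are shown below. What is called first, only, known or untested is meant among the compounds shown, and "the series" means these compounds.

Measured compounds in an ADME assay on TZM-b1 cells (Homo sapiens) for cytotoxicity, read by XTT assay, with a stated time of 3 days; a higher number here means that more compound is tolerated, a lower number that less compound is tolerated:

Compound 1 `Cc1nc(C(NC(=O)C(=O)Nc2ccc(Cl)cc2)C2CCNCC2)sc1CO` gives 81000 nM.
Compound 2 `Cc1ccc(NC(=O)C(=O)NC(c2nc(C)c(CCO)s2)C2CCCCN2)cc1F` gives > 85000 nM, which is a limit of the assay and not a number.
Compound 3 `Cc1nc(C(NC(=O)C(=O)Nc2ccc(Cl)cc2)C2CCCN2)sc1CO` gives 12400 nM.

Among the two numbers shown, compound 3 stands lowest, so it is the least tolerated of the pair. Among the measured compounds shown here, its nearest neighbour is compound 1, and the one measured step, a 6.5-fold lower number from compound 1 to compound 3 (0.82 log units; beyond the scatter), separates them. Compound 4 `Cc1nc(C(NC(=O)C(=O)Nc2ccc(Cl)cc2)C2CCCCN2)sc1CO` is the next compound, and it differs from compound 3 by piperidin-2-yl in place of pyrrolidin-2-yl on a saturated chain carbon bound to an amide-type nitrogen and an aromatic carbon.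

For the measured compounds named here, no measured step covers exactly this change. The step from compound 1 to compound 3 moved the attachment and shrank the ring at the same time and lowered the number; compound 2 carries the same piperidin-2-yl as compound 4, though on a different core, and there compound 2 reached only a limit (the limit of > 85000 nM in this assay, at which 1 of the 3 values shown sits). Taken together these point to a larger number for compound 4 than for compound 3, of the order of the step of a 3.2-fold higher number from compound 3 to compound 4 (0.51 log units; beyond the scatter) that is expected here. Compound 4 is therefore estimated at 40000 nM, between 12000 nM and 100000 nM.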

Compound 4, half-maximal cytotoxic concentration: > 22000 nM
Compound 4 ended at the assay's limit; the forecaster's own chance of this, stated with the estimate: 25%; the middle value is on the limit's open side.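

In this assay compound 4 gives > 22000 nM, which is a limit of the assay and not a number. Among the compounds shown here, with the attachment kept at the 2-yl position, this is the first direct reading of piperidin-2-yl in place of pyrrolidin-2-yl on the saturated chain carbon, and it gives an at least 1.7-fold higher number from compound 3 to compound 4 (0.24 log units; that floor lies within the scatter), so the readable floor of the step does not on its own separate the two rings. The step between piperidin-2-yl and piperidin-4-yl, which compares compound 1 with compound 4, cannot be read, so these two attachments stay unordered here: the limit of > 22000 nM in this assay, at which 1 of the 4 values shown sits.

The compounds shown leave open how far the true number for compound 4 lies past its limit. They also leave open how a piperazin-2-yl ring or an open-chain aminoethyl group on this same carbon would read in this assay.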